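Amide aryl variation on a shared thioacetamide scaffold

A few compounds are considered here, and "the series" means these few. Any claim that something is new, unique, unknown or untested is made for them only; others in the source may bear on it.

Compound 1 `O=C(CSc1nc(Nc2ccccc2)c2ccccc2n1)Nc1ccccc1F`: 12400 nM
Compound 2 `O=C(CSc1nc(Nc2ccccc2)c2ccccc2n1)Nc1cccc([N+](=O)[O-])c1`: 11800 nM
Compound 3 `CCc1cccc(NC(=O)CSc2nc(Nc3ccccc3)c3ccccc3n2)c1`: 11000 nM

Of the compounds shown here, three sharing one core have been tested in a functional assay on PC-3 cells (Homo sapiens) for inhibition, read by MTT assay, with a stated time of 72 h; on this read-out lower numbers stand for stronger inhibition and higher numbers for weaker inhibition. In this assay compound 1 gives 12400 nM, compound 2 gives 11800 nM and compound 3 gives 11000 nM. Compound 3 stands together with the other two inside the scatter: the step of a 1.1-fold lower number from compound 1 to compound 3 (0.05 log units; within the scatter) and the step of a 1.1-fold lower number from compound 2 to compound 3 (0.03 log units; within the scatter) are both too small to separate the compounds, as is the step of a 1.1-fold lower number from compound 1 to compound 2 (0.02 log units; within the scatter). On these numbers the group on the amide-type nitrogen has not moved the read-out.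

Compound 4 `O=C(CSc1nc(Nc2ccccc2)c2ccccc2n1)Nc1ccc(C(F)(F)F)cc1` differs from compound 3 in one place: 4-(trifluoromethyl)phenyl in place of 3-ethylphenyl on an amide-type nitrogen. The three measured steps all concern the same position and all stayed within the scatter, so they speak for a small or no change here as well. For the measured compounds named here, nothing among the measured compounds carries a trifluoromethyl group, so the estimate rests only on the flatness seen so far. Compound 4 is therefore expected to give about 11500 nM in this assay, with a range from 5000 nM to 26000 nM. The step this estimate implies, a 1.0-fold higher number from compound 3 to compound 4 (0.02 log units; within the scatter), is expected to lie within the scatter.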

Compound 4, half-maximal inhibitory concentration: 10400 nM
Beside the measured number, compound 4's estimate is 1.1-fold (0.04 log units) above it, within the range that was stated.
By their numbers in this assay, from the lowest: compounds 4, 3, 2 and 1 (each within the scatter of the next).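

In this assay the change to 4-(trifluoromethyl)phenyl on the amide-type nitrogen gives a 1.1-fold lower number from compound 3 to compound 4 (0.02 log units; within the scatter) and, measured against the other two groups, a 1.1-fold lower number from compound 2 to compound 4 (0.05 log units; within the scatter) and a 1.2-fold lower number from compound 1 to compound 4 (0.08 log units; within the scatter), so all three new steps stay within the scatter. The flat picture therefore now reaches beyond 2-fluorophenyl, 3-nitrophenyl and 3-ethylphenyl to a phenyl group carrying trifluoromethyl, and the larger group entering here, with fluorine in place of carbon-only substitution, leaves the four compounds inseparable at this position. Nothing available bears on why the read-out stays flat here.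

The compounds shown leave open whether any group on the amide-type nitrogen can separate itself from these four, since all of them carry a phenyl ring there with a single added group, and an amine or a carboxylic acid on that ring, or a longer alkyl chain in place of the ring, would test this. They also leave open how the read-out responds to changes elsewhere, as the rest of the shared core stays the same throughout.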